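Swapping the chain end of compound 3

The source may hold more compounds than are shown below. What is called first, only, known or untested is meant among the compounds shown, and "the series" means these compounds.

Measured in a functional assay on MCF7 cells (Homo sapiens) for antiproliferative activity, read by MTT assay; on this read-out lower numbers stand for stronger inhibition and higher numbers for weaker inhibition:
Compound 1 `CCCC/C=C\CCCCCCCCCc1cc(=O)c2c(O)cc(O)c(C)c2o1`: 17500 nM
Compound 2 `CCCCCCCCCCCCCCCC1(O)CC(=O)c2c(O)cc(O)cc2O1`: 17500 nM
Compound 3 `CC/C=C\C/C=C\C/C=C\CCCCCCCC1(O)CC(=O)c2c(O)cc(OCOC)cc2O1`: 17500 nM

Compound 3 stands level with compound 1 and compound 2, so these numbers set no order among the three. Compound 4 `CCCC/C=C\CCCCCCCCCC1(O)CC(=O)c2c(O)cc(OCOC)cc2O1` differs from compound 3 in one place, on a saturated chain carbon, seven bonds along the chain from a saturated ring carbon: a group of 8 heavy atoms (8 carbon; no ring) in place of a group of 10 heavy atoms (10 carbon; no ring), on a saturated chain carbon, seven bonds along the chain from a saturated ring carbon. Within the data shown here, no measured pair isolates this change. The chain of compound 4 also occurs in compound 1, which gives 17500 nM, so no step beyond the scatter is expected in this assay, in either direction. The expected result is no change at the digits printed from compound 3 to compound 4 (within the scatter). The estimate for compound 4 is 17500 nM, with an expected range from 8000 nM to 35000 nM.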

Compound 4, half-maximal inhibitory concentration: 43200 nM
Estimate against measurement, compound 4: 2.5-fold (0.39 log units) below; measured number above the stated range.
By their numbers in this assay, from the lowest: compounds 1, 2 and 3 (each within the scatter of the next); then compound 4.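

In this assay, the swap to oct-3-en-1-yl brings a 2.5-fold higher number from compound 3 to compound 4 (0.39 log units; beyond the scatter) and so means weaker inhibition, a modest loss. The earlier compounds shown here, level with one another, could not show that this stretch of the chain responds to change at all. Nothing measured here explains the step.

The swap alters chain length and the number of double bonds together, so the two effects cannot be told apart. Also open, going by these compounds, is how a longer chain, or a chain ending in a carboxylic acid or an amine, would behave here.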